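Anilide aryl variation: 3-ethylphenyl in place of 4-fluorophenyl

This account rests on a few compounds, and the source may have more. Where it says the series, first, only, none or still open, it means among the compounds named here.

Compound 3 `O=C(CN1CCC(c2cccc[n+]2[O-])CC1)Nc1ccc(F)cc1` gives 85 nM in a functional assay on HEK293 cells for agonist activity at D(4) dopamine receptor (Homo sapiens), read by FLIPR (a higher number here means that more compound is needed for the effect, a lower number that less compound is needed), the highest of the three numbers measured. Compound 1 `O=C(CN1CCC(c2cccc[n+]2[O-])CC1)Nc1cccc(Cl)c1` gives 62 nM, and compound 2 `Cc1cc(NC(=O)CN2CCC(c3cccc[n+]3[O-])CC2)ccc1F` gives 18 nM. The step of a 1.4-fold higher number from compound 1 to compound 3 (0.14 log units; within the scatter) lies within the scatter, so 3-chlorophenyl and 4-fluorophenyl read alike. The step of a 4.7-fold higher number from compound 2 to compound 3 (0.67 log units; beyond the scatter) is beyond the scatter, and a 3.4-fold lower number from compound 1 to compound 2 (0.54 log units; beyond the scatter) points the same way, both favouring an anilide that carries a methyl alongside the fluorine. Compound 4 `CCc1cccc(NC(=O)CN2CCC(c3cccc[n+]3[O-])CC2)c1` carries 3-ethylphenyl in place of 4-fluorophenyl on an amide-type nitrogen. Since the methyl of compound 2 gave a 4.7-fold higher number from compound 2 to compound 3 (0.67 log units; beyond the scatter) in reverse, an ethyl is expected to lower the number as well, by about a 2.8-fold lower number from compound 3 to compound 4 (0.45 log units; beyond the scatter). Compound 4 is therefore estimated at 30 nM, with a range of 10 nM to 90 nM.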

Compound 4, half-maximal effective concentration: 95 nM
Compound 4: the middle estimate sits 3.2-fold (0.50 log units) below what was measured; measured number outside the range, above it.
By their numbers in this assay, from the lowest: compound 2; then compounds 1, 3 and 4 (each within the scatter of the next).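

In this assay, 3-ethylphenyl on the amide-type nitrogen reads alike with 4-fluorophenyl (a 1.1-fold higher number from compound 3 to compound 4 (0.05 log units; within the scatter)), and ethyl reads alike with chloro on the aromatic carbon (a 1.5-fold higher number from compound 1 to compound 4 (0.19 log units; within the scatter)). An alkyl group on the aryl ring therefore does not by itself set a compound apart: among the four compounds, only compound 2, with 4-fluoro-3-methylphenyl, stands apart (a 5.3-fold higher number from compound 2 to compound 4 (0.72 log units; beyond the scatter)). No evidence at hand accounts for this result.

Open, going by these compounds, is whether methyl alone matches compound 2 or needs the fluorine. Also open, on these data alone, is how a propyl chain or a methoxy group would read in place of the ethyl.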